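Thiophen-3-yl for furan-3-yl on the shared core

A few compounds are considered here, and "the series" means these few. Any claim that something is new, unique, unknown or untested is made for them only; others in the source may bear on it.

Compound 1 `OC[C@H]1O[C@@H](n2cc(Cl)c3c(-c4ccccc4)ncnc32)[C@H](O)[C@@H]1O` carries phenyl on the shared core, and in a functional assay on HeLa S3 cells (Homo sapiens) for cytotoxicity, read by XTT assay, with a stated time of 3 days (on this read-out higher numbers stand for weaker inhibition and lower numbers for stronger inhibition), compound 1 gives 420 nM. Compound 2 `OC[C@H]1O[C@@H](n2cc(Cl)c3c(-c4ccco4)ncnc32)[C@H](O)[C@@H]1O` carries furan-2-yl in that place. In this assay compound 2 gives > 40000 nM, which is a limit of the assay and not a number. Compound 3 `OC[C@H]1O[C@@H](n2cc(Cl)c3c(-c4ccoc4)ncnc32)[C@H](O)[C@@H]1O` carries furan-3-yl, and in this assay compound 3 gives 2700 nM, the highest of the two numbers recorded, with compound 1 nearest. The move away from phenyl was a 6.4-fold higher number from compound 1 to compound 3 (0.81 log units; beyond the scatter); the move between the two furan isomers was an at least 14-fold lower number from compound 2 to compound 3 (1.17 log units; beyond the scatter).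

Compound 4 `OC[C@H]1O[C@@H](n2cc(Cl)c3c(-c4ccsc4)ncnc32)[C@H](O)[C@@H]1O` differs from compound 3 by thiophen-3-yl in place of furan-3-yl on an aromatic carbon. Both measured steps exchange one ring for another with the heteroatom of furan fixed, so neither maps directly onto a swap of oxygen for sulfur at the same position. Compound 4 is expected to fall between compound 1 and compound 3, a modest improvement on compound 3 that does not reach compound 1. The estimate for compound 4 is 1200 nM, with a range from 400 nM to 4000 nM. The expected step is a 2.3-fold lower number from compound 3 to compound 4 (0.35 log units; beyond the scatter).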

Compound 4, half-maximal inhibitory concentration: 340 nM
The estimate for compound 4 lay 3.5-fold (0.55 log units) above the measured number, outside the stated range (below it).
By their numbers in this assay, from the lowest: compounds 4 and 1 (each within the scatter of the next); then compound 3. At a limit, above all of these: compound 2.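

Exchanging furan-3-yl for thiophen-3-yl at this position in this assay gives a step beyond the scatter (a 7.9-fold lower number from compound 3 to compound 4 (0.90 log units; beyond the scatter)), so the ring hetero atom alone, with ring size and attachment point unchanged, moves the number. Thiophen-3-yl also shows that a five-membered aromatic ring here need not lose ground to phenyl (a 1.2-fold lower number from compound 1 to compound 4 (0.09 log units; within the scatter)), which neither furan showed. The step from compound 2 (an at least 110-fold lower number from compound 2 to compound 4 (2.07 log units; beyond the scatter)) starts from a value that is a limit of the assay and not a number, so its size is only a bound: the limit of > 40000 nM in this assay, at which 1 of the 4 values shown sits.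

The compounds shown leave open whether thiophen-2-yl would recover what furan-2-yl lost. They also give no reading for a nitrogen-containing ring at this position, such as pyrrol-3-yl or pyridin-3-yl.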